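Series notes: phenylsulfonyl substitution and compound 4

A few compounds are considered here, and "the series" means these few. Any claim that something is new, unique, unknown or untested is made for them only; others in the source may bear on it.

Of the compounds shown here, three of the shared core have been measured in an assay on HeLa cells for displacement of a labelled ligand from 5-hydroxytryptamine receptor 6 (Homo sapiens); a higher number here means a weaker inhibitor, a lower number a stronger inhibitor. Compound 1 `Cc1cccc(S(=O)(=O)c2ccc3[nH]nc(C4CCN(C)CC4)c3c2)c1` gives 50 nM, compound 2 `CN1CCC(c2n[nH]c3ccc(S(=O)(=O)c4ccccc4)cc23)CC1` gives 55 nM, and compound 3 `CN1CCC(c2n[nH]c3ccc(S(=O)(=O)c4ccc(F)cc4)cc23)CC1` gives 66 nM. Compound 3 carries the highest of the three numbers, but its nearest neighbour is compound 2 and its furthest is compound 1, and both gaps lie within the scatter, so no order among the three can be claimed.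

Compound 4 `CN1CCC(c2n[nH]c3ccc(S(=O)(=O)c4ccc(OC(F)(F)F)cc4)cc23)CC1` is not yet measured. Relative to compound 3 the change is trifluoromethoxy in place of fluoro on an aromatic carbon. Going by the values given here, the steps that bear on this position are a 1.2-fold higher number from compound 2 to compound 3 (0.08 log units; within the scatter) and a 1.3-fold higher number from compound 1 to compound 3 (0.12 log units; within the scatter), with a 1.1-fold higher number from compound 1 to compound 2 (0.04 log units; within the scatter) at the other ring position; none of them moved this assay beyond the scatter, so substitution on the sulfonyl-bound phenyl has so far left the numbers essentially flat. The step to trifluoromethoxy is larger in size than any measured one, so the expectation is a small shift, if any, toward a higher number, with the step of a 1.2-fold higher number from compound 3 to compound 4 (0.08 log units; within the scatter) still expected to lie near the scatter. For compound 4 the estimate is 80 nM, with a range from 30 nM to 220 nM.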

Compound 4, inhibition constant: 48 nM
For compound 4 the middle estimate is 1.7-fold (0.22 log units) above the measured one; the range from low to high includes it.
By their numbers in this assay, from the lowest: compounds 4, 1, 2 and 3 (each within the scatter of the next).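

The trifluoromethoxy group brings five heavy atoms and one hydrogen-bond acceptor where fluoro has one heavy atom and no acceptor, yet in this assay both new steps stay within the scatter (a 1.4-fold lower number from compound 3 to compound 4 (0.14 log units; within the scatter); a 1.1-fold lower number from compound 2 to compound 4 (0.06 log units; within the scatter)). Going by these compounds alone, this extends the flat reading at this place, on an aromatic carbon para to a large group, to a much larger substituent: hydrogen in compound 2, fluoro in compound 3 and trifluoromethoxy in compound 4 cannot be told apart in this assay, and no compound goes against that reading. No evidence is available on what lies behind this flatness.

As far as these compounds go, whether an amine or a carboxylic acid at this place would also stay within the scatter remains open. Also open, from the compounds shown here alone, is whether trifluoromethoxy would read the same at the ring position that carries methyl in compound 1.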